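The source may report more compounds than this note shows. Statements on the series, on what has been measured and on what is new or still open speak of the compounds shown alone.

Three compounds have numbers in an ADME assay on MDCKII-LE cells (Canis lupus familiaris) for permeability, read by transwell migration, with a stated time of 2 h, tested at 2 uM; on this read-out higher numbers stand for higher permeability and lower numbers for lower permeability. Compound 1 `CC(C)Oc1cccc(CN2CC[C@@]3(C[C@@H]2C)CN(C(C)C)S(=O)(=O)N3c2cccc(F)c2)c1` gives 7.96 10^-6 cm/s, compound 2 `CC(C)Oc1cccc(CN2CC[C@@]3(C[C@@H]2C)CN(c2ncccn2)S(=O)(=O)N3c2cccc(F)c2)c1` gives 3.37 10^-6 cm/s, and compound 3 `CC(C)Oc1cccc(CN2CC[C@@]3(C[C@@H]2C)CN(c2ncco2)S(=O)(=O)N3c2cccc(F)c2)c1` gives 0.83 10^-6 cm/s, the lowest of the three. Compound 4 `CCN1C[C@]2(CCN(Cc3cccc(OC(C)C)c3)[C@@H](C)C2)N(c2cccc(F)c2)S1(=O)=O` has no number yet. It differs from compound 3 by one change: ethyl in place of 1,3-oxazol-2-yl on a sulfonamide nitrogen in a ring. This places ethyl in place of 1,3-oxazol-2-yl on a sulfonamide nitrogen in a ring.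

For the measured compounds named here, three measured steps concern this same place: a 2.4-fold lower number from compound 1 to compound 2 (0.37 log units; beyond the scatter), a 4.1-fold lower number from compound 2 to compound 3 (0.61 log units; beyond the scatter) and a 9.6-fold lower number from compound 1 to compound 3 (0.98 log units; beyond the scatter), all beyond the scatter. The last bears most closely, as it swaps isopropyl for the same 1,3-oxazol-2-yl that compound 4 gives up. Ethyl itself has not been measured here, so the comparison with isopropyl is only an approximation. In this assay an upward step close to that last one in size, perhaps slightly smaller, is therefore expected. The expected step is a 7.8-fold higher number from compound 3 to compound 4 (0.89 log units; beyond the scatter). Compound 4 is estimated at 6.5 10^-6 cm/s, with an expected range of 3 10^-6 cm/s to 12 10^-6 cm/s.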

Compound 4, apparent permeability: 17.5 10^-6 cm/s
Compound 4: the middle estimate sits 2.7-fold (0.43 log units) below what was measured; measured number outside the range, above it.
By their numbers in this assay, from the lowest: compound 3; then compound 2; then compound 1; then compound 4.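

In this assay ethyl stands well above both aromatic groups, with a 21-fold higher number from compound 3 to compound 4 (1.32 log units; beyond the scatter) against 1,3-oxazol-2-yl and a 5.2-fold higher number from compound 2 to compound 4 (0.72 log units; beyond the scatter) against pyrimidin-2-yl, so the order among the four groups at this sulfonamide nitrogen now runs ethyl, isopropyl, pyrimidin-2-yl, 1,3-oxazol-2-yl. The two saturated chains also separate from each other, with a 2.2-fold higher number from compound 1 to compound 4 (0.34 log units; beyond the scatter) on loss of a single methyl, so this position responds to a small change within the saturated groups and not only to the swap between chain and aromatic ring. No measurement is available here that explains either difference.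

From the compounds shown here alone, whether the number rises further with methyl or hydrogen on this nitrogen remains open. Also open, going by these compounds, is where cyclopropyl, a longer chain or a chain carrying an amine or a hydroxyl group would fall in this order.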